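The source may hold more compounds than are shown below. What is called first, only, known or untested is meant among the compounds shown, and "the series" means these compounds.

Compounds measured in this study:

compound 1 `O=c1[nH]cnc2c1c(-c1ccoc1)cn2[C@@H]1O[C@H](CO)[C@@H](O)[C@H]1O` — > 100000 nM
compound 2 `O=c1[nH]cnc2c1c(-c1ccsc1)cn2[C@@H]1O[C@H](CO)[C@@H](O)[C@H]1O` — > 100000 nM
compound 3 `Cc1nc(N)c2c(I)cn([C@@H]3O[C@H](CO)[C@@H](O)[C@H]3O)c2n1` — 85800 nM

In an ADME assay on MRC5 cells (Homo sapiens), read by MTT assay, with a stated time of 72 h (on this read-out lower numbers stand for stronger inhibition and higher numbers for weaker inhibition), compound 1 reaches only a limit of the assay, > 100000 nM. Compound 2 likewise stops at a limit, > 100000 nM. Compound 3 gives a number, 85800 nM. Compound 2 thus stands at the ceiling of the assay, where two of the three values sit (the limit of > 100000 nM in this assay, at which 2 of the 3 values shown sit), and nothing places it above or below compound 1. Among the measured compounds shown here, the single step between measured compounds, a step that the two limits leave unreadable from compound 1 to compound 2, cannot be read, as both ends are limits.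

Compound 4 `O=c1[nH]cnc2c1c(-c1cc3ccccc3o1)cn2[C@@H]1O[C@H](CO)[C@@H](O)[C@H]1O` differs from compound 2 by 1-benzofuran-2-yl in place of thiophen-3-yl on an aromatic carbon. For the measured compounds named here, no measured step speaks to this change; the only neighbouring step is the unreadable one just named. The account therefore expects compound 4 to remain where compound 2 stands, with a step of a number no higher from compound 2 to compound 4 (the limit leaves the size open) that is not expected to exceed the scatter, and most probably another limit rather than a number. Compound 4 is estimated at 100000 nM, within 40000 nM to 300000 nM.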

Compound 4, half-maximal inhibitory concentration: > 100000 nM
Compound 4 gave a limit, no number (the forecaster's own chance of this, stated with the estimate: 75%); the middle value sits exactly at the limit.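

In this assay compound 4 gives > 100000 nM, a limit and not a number. Its steps from compound 1 and compound 2 therefore cannot be read, as both ends of each are limits: the limit of > 100000 nM in this assay, at which 3 of the 4 values shown sit.

The compounds shown leave open whether 1-benzofuran-2-yl, thiophen-3-yl and furan-3-yl differ at all in this assay.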